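The source may hold more compounds than are shown below. What is called first, only, known or untested is meant among the compounds shown, and "the series" means these compounds.

Compound 1 `FC1(F)CCC(NC/C=C/CN(C[C@H]2Cc3ccccc3CN2)[C@H]2CCCc3cccnc32)CC1` and compound 2 `C(=C/CN(C[C@H]1Cc2ccccc2CN1)[C@H]1CCCc2cccnc21)\CNC1CCOCC1` share one core and differ at a single place: oxan-4-yl in place of 4,4-difluorocyclohexyl on an amine nitrogen. In a functional assay on cells for antagonist activity at C-X-C chemokine receptor type 4 (Homo sapiens), read by fluorescence and calcium flux, with stated times of 25 min and 90 s (on this read-out lower numbers stand for stronger inhibition and higher numbers for weaker inhibition), compound 1 gives 82.1 nM, while compound 2 gives 15.5 nM, which is a 5.3-fold lower number from compound 1 to compound 2 (0.72 log units; beyond the scatter). Compound 3 `CC(C)(CCN(C[C@H]1Cc2ccccc2CN1)[C@H]1CCCc2cccnc21)CNC1CCC(F)(F)CC1` carries the same 4,4-difluorocyclohexyl group on a different core; the difference between the two cores is not broken down here. In this assay compound 3 gives 168 nM, the highest number among the three. Compound 4 `CC(C)(CCN(C[C@H]1Cc2ccccc2CN1)[C@H]1CCCc2cccnc21)CNC1CCOCC1` has not yet been measured; it differs from compound 3 by the same change, at the same place: oxan-4-yl in place of 4,4-difluorocyclohexyl on an amine nitrogen. The step from compound 3 to compound 4 is expected to be a 4.8-fold lower number from compound 3 to compound 4 (0.68 log units; beyond the scatter), a size carried over from a 5.3-fold lower number from compound 1 to compound 2 (0.72 log units; beyond the scatter). Compound 4 is therefore estimated at 35 nM, with a likely range from 15 nM to 90 nM.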

Compound 4, half-maximal inhibitory concentration: 36.3 nM
Compound 4: the middle estimate sits 1.0-fold (0.02 log units) below what was measured; the range from low to high includes it.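

In this assay putting oxan-4-yl in place of 4,4-difluorocyclohexyl on the amine nitrogen gives a 4.6-fold lower number from compound 3 to compound 4 (0.67 log units; beyond the scatter) on the second core. Set beside the earlier step, the change carries from one core to the other with its size kept: the same change on two cores in this assay, a 5.3-fold lower number (0.72 log units; beyond the scatter) from compound 1 to compound 2 and a 4.6-fold lower number (0.67 log units; beyond the scatter) from compound 3 to compound 4, 1.1-fold (0.06 log units) apart, within the scatter of two such steps. This rests on only two pairs of compounds in one assay, so it says nothing about cores not shown here, and it does not explain why the oxan-4-yl compounds give the lower numbers.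

The compounds shown leave open whether other groups on this amine nitrogen, such as a plain cyclohexyl or a piperidin-4-yl ring, would behave the same way on both cores.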